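The compounds below may be only part of what the source reports. "The series", "measured", "known", "first", "only" and "open" are said of these compounds alone.

Measured compounds:
- Compound 1 `CCNC(=O)NC1=CS(=O)(=O)O[C@@]12[C@@H](CO[Si](C)(C)C(C)(C)C)O[C@@H](n1cc(C)c(=O)n(C)c1=O)[C@@H]2O[Si](C)(C)C(C)(C)C`: in a functional assay on HEL cells (Homo sapiens) for cytotoxicity, read by microscopy (on this read-out lower numbers stand for higher toxicity in this test and higher numbers for lower toxicity in this test), compound 1 gives >= 3200 nM, a limit of the assay.
- Compound 2 `Cc1cn([C@@H]2O[C@H](CO[Si](C)(C)C(C)(C)C)[C@@]3(OS(=O)(=O)C=C3NCCC(=O)OCc3ccccc3)[C@H]2O[Si](C)(C)C(C)(C)C)c(=O)n(C)c1=O`: in this assay compound 2 gives >= 400000 nM, also a limit of the assay.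
- Compound 3 `Cc1cn([C@@H]2O[C@H](CO[Si](C)(C)C(C)(C)C)[C@@]3(OS(=O)(=O)C=C3NC(N)=O)[C@H]2O[Si](C)(C)C(C)(C)C)c(=O)n(C)c1=O`: in this assay compound 3 gives 16000 nM, the only number in the set.

Compound 3 therefore stands alone as a measured figure; the other two values sit at limits, the limit of >= 3200 nM in this assay, at which 1 of the 3 values shown sits, and (the limit of >= 400000 nM in this assay, at which 1 of the 3 values shown sits), so the steps a step that the two limits leave unreadable from compound 1 to compound 2 and a step that the limit leaves unreadable from compound 1 to compound 3 cannot be sized. Among the compounds with values here, the one readable step is an at least 25-fold lower number from compound 2 to compound 3 (1.39 log units; beyond the scatter).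

Compound 4 `COC(=O)CNC1=CS(=O)(=O)O[C@@]12[C@@H](CO[Si](C)(C)C(C)(C)C)O[C@@H](n1cc(C)c(=O)n(C)c1=O)[C@@H]2O[Si](C)(C)C(C)(C)C` is not yet measured. It differs from compound 3 by (methoxycarbonyl)methyl in place of carbamoyl on an amine nitrogen. The step that bears on it is an at least 25-fold lower number from compound 2 to compound 3 (1.39 log units; beyond the scatter): compound 2, carrying 2-(benzyloxycarbonyl)ethyl on the amine nitrogen, sat at the limit, while carbamoyl in compound 3 brought the number down strongly. (Methoxycarbonyl)methyl in compound 4 is a shorter chain of the same kind as in compound 2, so the expectation is a move back upward, partly reversing that step, though the limit in compound 2 makes the full size unreadable. The estimated step is a 6.3-fold higher number from compound 3 to compound 4 (0.80 log units; beyond the scatter). Compound 4 is expected to give about 100000 nM in this assay, within 20000 nM to 400000 nM.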

Compound 4, minimum cytotoxic concentration: >= 400000 nM
Compound 4 ended at the assay's limit; the forecaster's own chance of this, stated with the estimate: 40%; at least 4.0-fold (0.60 log units) between middle value and limit.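

In this assay, (methoxycarbonyl)methyl in place of carbamoyl on the amine nitrogen gives an at least 25-fold higher number from compound 3 to compound 4 (1.39 log units; beyond the scatter), so this position now shows a large change in both directions around the carbamoyl compound. Until now, only the 2-(benzyloxycarbonyl)ethyl chain of compound 2 had placed an ester-bearing chain at the top of the readable range; compound 4 shows that the shorter (methoxycarbonyl)methyl chain, with its methyl ester, does not bring the number back into that range. Compound 2 and compound 4 therefore end at the same limit, which is a limit and not a measured number: the limit of >= 400000 nM in this assay, at which 2 of the 4 values shown sit.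

The steps from compound 2 to compound 4 and from compound 1 to compound 4 cannot be read, so the two ester chains cannot be ranked, and compound 1, which carries ethylcarbamoyl on the same nitrogen, gives no number to set beside compound 3. Open too, as far as these compounds go, is whether the measured value of compound 3 depends on the ureido group as a whole, which a plain amine, an acetyl group or a free carboxylic acid on the chain at this nitrogen would begin to separate.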